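The compounds below may be only part of what the source reports. "The series", "measured", "known", "first", "only" and "open" are said of these compounds alone.

Measured in a functional assay on HT-29 cells (Homo sapiens) for cytotoxicity, read by MTT assay, with a stated time of 48 h; a higher number here means a weaker inhibitor, a lower number a stronger inhibitor:
- compound 1 `OC[C@@H]1C[C@H](CO)[C@@H]2C(c3ccc(Cl)cc3)=NO[C@H]12` gives 22.9 ug/mL
- compound 2 `N#Cc1ccc(C2=NO[C@@H]3[C@H](CO)C[C@H](CO)[C@H]23)cc1` gives > 50 ug/mL (a limit)

Compound 2 has no number in this assay, only the limit > 50 ug/mL. Compound 3 `COc1ccc(C2=NO[C@@H]3[C@H](CO)C[C@H](CO)[C@H]23)cc1` carries methoxy in place of cyano on an aromatic carbon. Among the measured compounds shown here, one measured step bears on this place, cyano in place of chloro, an at least 2.1-fold higher number from compound 1 to compound 2 (0.33 log units; beyond the scatter), which is at least modest. Methoxy is therefore expected to give a modest step to a lower number in this assay, with little certainty. The estimated step is an at least 1.4-fold lower number from compound 2 to compound 3 (0.15 log units; that floor lies within the scatter). For compound 3 the expected value is 35 ug/mL, with an estimated range of 15 ug/mL to 80 ug/mL.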

Compound 3, half-maximal inhibitory concentration: > 50 ug/mL
Compound 3 gave a limit, no number (the forecaster's own chance of this, stated with the estimate: 35%); middle value at least 1.4-fold (0.15 log units) away from the limit.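

In this assay, methoxy in place of chloro gives an at least 2.1-fold higher number from compound 1 to compound 3 (0.33 log units; beyond the scatter), so a second replacement on this aromatic carbon also moves away from compound 1. Chloro is thus the only group at this position with a number so far. Cyano and methoxy cannot be ranked, and the step between compound 2 and compound 3 cannot be read: the limit of > 50 ug/mL in this assay, at which 2 of the 3 values shown sit.

As far as these compounds go, whether any group at this position gives a lower number than chloro remains open. A bromo group, an amine or a carboxylic acid here would test whether chloro is unusual in keeping a measurable value.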